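Replacing a hydroxypropyl chain with an aryl ring

The compounds below may be only part of what the source reports. "The series", "measured", "known", "first", "only" and "open" are said of these compounds alone.

Compound 1, `CCCCCCCCc1cn(C(c2ccccc2)c2cc3cc(Br)ccc3nc2OC)nn1`, gives 12.1% in an ADME assay on PANC-1 cells (Homo sapiens) for cytotoxicity, read by sulforhodamine B assay, with a stated time of 48 h, tested at 10 uM; on this read-out higher numbers stand for more inhibition at the one concentration tested (going by the name of the read-out) and lower numbers for less inhibition.
Compound 2, `CCCCCc1cn(C(c2ccccc2)c2cc3cc(Br)ccc3nc2OC)nn1`, gives 5.07% in this assay.
Compound 3, `COc1nc2ccc(Br)cc2cc1C(c1ccccc1)n1cc(CCCO)nn1`, gives 25.5% in this assay.

Among these three, compound 3 stands highest: the step of a number 13.4 percentage points higher from compound 1 to compound 3 (beyond the scatter) and the step of a number 20.4 percentage points higher from compound 2 to compound 3 (beyond the scatter) both lie beyond the scatter, while compound 1 and compound 2 are separated only by a number 7 percentage points lower from compound 1 to compound 2 (within the scatter), so nothing can be said about their order. Going by the values given here, the only compound carrying a hydroxy on its chain is also the one with the largest number.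

Compound 4, `COc1nc2ccc(Br)cc2cc1C(c1ccccc1)n1cc(-c2ccc(OC(F)(F)F)cc2)nn1`, differs from compound 3 by 4-(trifluoromethoxy)phenyl in place of 3-hydroxypropyl on an aromatic carbon. Among the compounds with values here, the two steps that end at compound 3 bear on this change in that both alter the same part of the structure and both remove or add the hydroxy-bearing chain; the new ring, however, has no measured counterpart here, so the expectation is loose. Since the hydroxy is lost, a modest fall towards the numbers of compound 1 and compound 2 seems more likely than a rise. Compound 4 is therefore expected to give about 15%, within the range 0% to 35%. This estimate means a number 10.5 percentage points lower from compound 3 to compound 4 (beyond the scatter) is expected.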

Compound 4, a percentage reported as inhibition, at one concentration (the size of the read-out at that concentration, not a potency): 11.7%
Compound 4: middle estimate off by 3.3 percentage points, on the high side; the range from low to high includes it.
By their numbers in this assay, from the lowest: compounds 2, 4 and 1 (each within the scatter of the next); then compound 3.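

In this assay, this aromatic carbon of the five-membered ring accepts a large aryl group in place of a short chain, but the exchange of 3-hydroxypropyl for 4-(trifluoromethoxy)phenyl gives a number 13.8 percentage points lower from compound 3 to compound 4 (beyond the scatter) and so does not hold the number reached with the hydroxy chain. Against the plain chains, the same ring gives a number 6.6 percentage points higher from compound 2 to compound 4 (within the scatter) and a number 0.4 percentage points lower from compound 1 to compound 4 (within the scatter), so compound 4 cannot be told apart from either the pentyl or the octyl compound. Among these four compounds, a saturated chain and an aromatic ring without a hydroxy therefore read alike, and only compound 3, the one compound with a hydrogen-bond donor on this substituent, stands apart, with no compound going against that pattern.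

Nothing available here gives a reason for the lower number of compound 4. From the compounds shown here alone, the step from compound 3 to compound 4 brings in a ring and removes the hydroxy together, so it remains open which of the two matters, a question that a phenyl ring carrying a hydroxy group, or a propyl chain ending in an amine, would help to separate.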